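The source may report more compounds than this note shows. Statements on the series, on what has been measured and on what is new or still open speak of the compounds shown alone.

Measured so far:
- Compound 1 `CCCCCCCCc1ccc(OCC(=O)Cn2ncc3ccccc32)cc1`, in an assay on microsomes from brain for inhibition of Fatty-acid amide hydrolase 1 (Rattus norvegicus), read by fluorescence and HPLC, with a stated time of 60 min (a higher number here means a weaker inhibitor, a lower number a stronger inhibitor), compound 1 gives 2300 nM.
- Compound 2 `CCCCCCCCc1ccc(OCC(=O)Cn2cnc3ccccc32)cc1`, compound 2 gives 480 nM.
- Compound 3 `CCCCCCCCc1ccc(OCC(=O)Cn2nnc3cccnc32)cc1`, compound 3 gives 13 nM.

Compound 1 has the highest number of the three, so it is the weakest inhibitor here. Its nearest neighbour is compound 2, with a 4.8-fold lower number from compound 1 to compound 2 (0.68 log units; beyond the scatter); compound 3 lies furthest away, with a 180-fold lower number from compound 1 to compound 3 (2.25 log units; beyond the scatter). Compound 4 `CCCCCCCCc1ccc(OCC(=O)Cn2ccc3ncccc32)cc1` keeps the same atoms as compound 1 but joins them differently: a group of 9 heavy atoms (7 carbon, 2 nitrogen; one five-membered aromatic ring with 1 hetero atom, one six-membered aromatic ring with 1 hetero atom) in place of a group of 9 heavy atoms (7 carbon, 2 nitrogen; one five-membered aromatic ring with 2 hetero atoms, one six-membered aromatic ring of carbon only), on a saturated chain carbon bound to a carbonyl carbon. Both measured steps replace the group at this same place, and both lower the number, one modestly and one by a large amount. The entering group shares with compound 3 a six-membered aromatic ring with one hetero atom, yet its five-membered ring carries fewer hetero atoms than either measured replacement. A lowering between those two steps is therefore expected, a 7.7-fold lower number from compound 1 to compound 4 (0.88 log units; beyond the scatter). Compound 4 is estimated at 300 nM, with a range from 60 nM to 1500 nM.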

Compound 4, half-maximal inhibitory concentration: > 10000 nM
Compound 4: no number, only a limit; the forecaster's own chance of this, stated with the estimate: 0%; middle value at least 33-fold (1.52 log units) from the limit.
By their numbers in this assay, from the lowest: compound 3; then compound 2; then compound 1. At a limit, above all of these: compound 4.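

Compound 4 gives no number, only a limit: the limit of > 10000 nM in this assay, at which 1 of the 4 values shown sits. The step runs opposite to the earlier ones, with an at least 4.3-fold higher number from compound 1 to compound 4 (0.63 log units; beyond the scatter), so at this place the same atoms joined differently can weaken inhibition as well as strengthen it. A six-membered aromatic ring with one hetero atom, shared with compound 3, does not by itself bring strong inhibition, with an at least 760-fold higher number from compound 3 to compound 4 (2.88 log units; beyond the scatter), and the gap is also large in an at least 20-fold higher number from compound 2 to compound 4 (1.31 log units; beyond the scatter).

As far as these compounds go, how weak compound 4 truly is stays open. So does whether a benzotriazol-1-yl group, with carbon only in its six-membered ring, would keep the strength of compound 3.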